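Quinoline amide series: aryl change on the pyrazole nitrogen

The source may hold more compounds than are shown below. What is called first, only, known or untested is meant among the compounds shown, and "the series" means these compounds.

Compound 3 `Cc1c(C(=O)Nc2ccc3ccccc3n2)cnn1-c1ccccc1F` gives 33300 nM in a functional assay on SW480 cells (Homo sapiens) for inhibition (a lower number here means a stronger inhibitor of growth, a higher number a weaker inhibitor of growth), and has the highest number of the three measured. Compound 1 `Cc1cccc(C)c1-n1ncc(C(=O)Nc2ccc3ccccc3n2)c1C` gives 7200 nM and compound 2 `Cc1c(C(=O)Nc2ccc3ccccc3n2)cnn1-c1c(F)cccc1Br` gives 3900 nM. The change to compound 4 `Cc1ccc(C)c(-n2ncc(C(=O)Nc3ccc4ccccc4n3)c2C)c1` is 2,5-dimethylphenyl in place of 2-fluorophenyl on an aromatic nitrogen. The nearest measured steps run the other way: a 4.6-fold higher number from compound 1 to compound 3 (0.67 log units; beyond the scatter) and an 8.5-fold higher number from compound 2 to compound 3 (0.93 log units; beyond the scatter), both with a smaller aryl group arriving. Compound 4 brings a two-methyl aryl group back, though not in the pattern of compound 1, so a modest downward step is expected, a 2.8-fold lower number from compound 3 to compound 4 (0.44 log units; beyond the scatter), with wide uncertainty. Compound 4 is estimated at 12000 nM in this assay, with a range from 4000 nM to 36000 nM.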

Compound 4, concentration for 50% growth inhibition: 24600 nM
For compound 4 the middle estimate is 2.1-fold (0.31 log units) below the measured one; measured number inside the range.
By their numbers in this assay, from the lowest: compounds 2 and 1 (each within the scatter of the next); then compounds 4 and 3 (each within the scatter of the next).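

In this assay, 2,5-dimethylphenyl on the aromatic nitrogen does not separate from 2-fluorophenyl (a 1.4-fold lower number from compound 3 to compound 4 (0.13 log units; within the scatter)). The same group stands clearly apart from the other two aryl groups (a 3.4-fold higher number from compound 1 to compound 4 (0.53 log units; beyond the scatter); a 6.3-fold higher number from compound 2 to compound 4 (0.80 log units; beyond the scatter)), so among these compounds, carrying two methyl groups does not by itself keep the number of compound 1; their placement on the aryl ring counts. No evidence at hand bears on the reason for this.

Still open, from the compounds shown here alone, is whether a methoxy or an amine on this aryl ring would hold or lower the number, and whether any such gain would carry over to other cell lines.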